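The source may hold more compounds than are shown below. What is called first, only, known or untested is meant among the compounds shown, and "the series" means these compounds.

Within the data shown here, compound 1 `O=[N+]([O-])c1ccc(-c2nc3cc(C(F)(F)F)ccc3[nH]2)cc1` gives 6000 nM in an ADME assay on MDBK cells (Bos taurus) for cytotoxicity, read by MTT assay, with a stated time of 96 h (a lower number here means that less compound is tolerated, a higher number that more compound is tolerated), the lowest of the two numbers so far. Compound 2 `O=[N+]([O-])c1ccc(-c2nc3cc(C(F)(F)F)ccc3n2C2CCCCC2)cc1` gives 68000 nM, and the step of an 11-fold higher number from compound 1 to compound 2 (1.05 log units; beyond the scatter) concerns a change at a different place. Among the measured compounds shown here, compound 3 `O=C(CCl)Nc1ccc(-c2nc3cc(C(F)(F)F)ccc3[nH]2)cc1` differs from compound 1 by ((chloromethyl)carbonyl)amino in place of nitro on an aromatic carbon No measured step covers a change at this place, so the series gives no direction for this assay here. For compound 3 the expected step is a 2.0-fold lower number from compound 1 to compound 3 (0.30 log units; within the scatter), judged largely within the scatter but open on either side. The estimate for compound 3 is 3000 nM, range 600 nM to 15000 nM.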

Compound 3, half-maximal cytotoxic concentration: 17000 nM
Compound 3: middle estimate off by 5.7-fold (0.75 log units), on the low side; measured number above the stated range.
By their numbers in this assay, from the lowest: compound 1; then compound 3; then compound 2.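

At this place, on an aromatic carbon para to a large group, ((chloromethyl)carbonyl)amino in place of nitro gives a 2.8-fold higher number from compound 1 to compound 3 (0.45 log units; beyond the scatter) in this assay. The position therefore affects this number, and the first change read here moves it upward, beyond the scatter. Nothing on hand bears on what lies behind this step.

From the compounds shown here alone, whether the step follows from losing nitro or from the chloromethyl end of the entering group stays open; a plain amine or an acetamide at this place would separate the two. Also open, going by these compounds, is how this change combines with cyclohexyl on the aromatic nitrogen.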